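Ring nitrogen placement drives Nrf2 activation in sulfone series

This account rests on a few compounds, and the source may have more. Where it says the series, first, only, none or still open, it means among the compounds named here.

Compound 1 `COc1ccccc1S(=O)(=O)/C=C/c1cccnc1`: > 10000 nM
Compound 2 `COc1ccccc1S(=O)(=O)/C=C/c1ccncc1`: 1520 nM

The study measures activation in an assay on U2OS cells for activation of nuclear factor erythroid 2-related factor 2 (Homo sapiens), read by chemiluminescence, with a stated time of 6 h; on this read-out lower numbers stand for an effect already at smaller amounts and higher numbers for an effect only at larger amounts of compound. Compound 1 `COc1ccccc1S(=O)(=O)/C=C/c1cccnc1` reaches only a limit of the assay in this assay, > 10000 nM. Compound 2 `COc1ccccc1S(=O)(=O)/C=C/c1ccncc1` gives 1520 nM in this assay, the only number shown in the set. Within the data shown here, the single measured step, an at least 6.5-fold lower number from compound 1 to compound 2 (0.81 log units; beyond the scatter), shows that moving the ring nitrogen within the six-membered aromatic ring on the double-bonded chain carbon changed the read-out by the limit of > 10000 nM in this assay, at which 1 of the 2 values shown sits, at least as far as the limit allows one to see.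

Compound 3 `COc1ccccc1S(=O)(=O)/C=C/c1cncnc1` is not yet measured. It differs from compound 2 as follows: pyrimidin-5-yl in place of pyridin-4-yl on a double-bonded chain carbon bound to a double-bonded chain carbon. The step from compound 1 to compound 2 is the only one that bears on this change, and it was at least modest and beyond the scatter. Since one of the two ring nitrogens of pyrimidin-5-yl is not where the nitrogen of pyridin-4-yl stood, a weaker value is expected for compound 3, with a step of a 3.3-fold higher number from compound 2 to compound 3 (0.52 log units; beyond the scatter) estimated. Compound 3 is therefore estimated at 5000 nM in this assay, within 1500 nM to 20000 nM.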

Compound 3, half-maximal effective concentration: > 10000 nM
Compound 3 was reported as a limit; the forecaster's own chance of this, stated with the estimate: 35%; at least 2.0-fold (0.30 log units) between middle value and limit.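

At the place on a double-bonded chain carbon bound to a double-bonded chain carbon, pyrimidin-5-yl in place of pyridin-4-yl gives an at least 6.5-fold higher number from compound 2 to compound 3 (0.81 log units; beyond the scatter), so a six-membered aromatic ring with 2 hetero atoms does not keep the read-out of compound 2. In this assay compound 3 gives > 10000 nM, which is a limit of the assay and not a number. Of the three rings shown at this place, only pyridin-4-yl yields a measured number, so the earlier step is not explained simply by having a ring nitrogen present, and most of the set now rests at the assay's limit: the limit of > 10000 nM in this assay, at which 2 of the 3 values shown sit.

Compound 1 and compound 3 both stand at a limit, and the step between them cannot be read, so the pyridin-3-yl and pyrimidin-5-yl groups cannot be ranked against each other. From the compounds shown here alone, it stays open whether a plain phenyl ring at this place, or an amine or a carboxylic acid carried on the pyridin-4-yl ring, would keep, improve or lose the read-out of compound 2.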